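The source may hold more compounds than are shown below. What is called first, only, known or untested is meant among the compounds shown, and "the series" means these compounds.

Compound 1 `Clc1ccc(NCc2cn(-c3ccccc3)nc2-c2ccc(Cl)cc2)cc1`: > 100000 nM
Compound 2 `FC(F)(F)c1ccc(NCc2cn(-c3ccccc3)nc2-c2ccc(C(F)(F)F)cc2)cc1`: 26000 nM

Among the compounds with values here, in an ADME assay on MDBK cells (Bos taurus) for cytotoxicity, read by MTT assay, with a stated time of 72 h (a lower number here means that less compound is tolerated, a higher number that more compound is tolerated), compound 2 gives 26000 nM, the only plain number among the values shown. In this assay compound 1 gives > 100000 nM, which is a limit of the assay and not a number. Compound 3 `FC(F)(F)c1ccc(NCc2cn(-c3ccccc3)nc2-c2ccc(Cl)cc2)cc1` has not yet been measured and differs from compound 2 by chloro in place of trifluoromethyl on an aromatic carbon. Compound 1 also carries chloro at that place, and its limit of > 100000 nM in this assay, at which 1 of the 2 values shown sits, points toward higher tolerance. The step is expected to run upward, a 2.3-fold higher number from compound 2 to compound 3 (0.36 log units; beyond the scatter), beyond the usual scatter. Compound 3 is therefore estimated at 60000 nM, within 20000 nM to 150000 nM.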

Compound 3, half-maximal cytotoxic concentration: 31000 nM
The estimate for compound 3 lay 1.9-fold (0.29 log units) above the measured number; the range from low to high includes it.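

In this assay, chloro in place of trifluoromethyl at this place gives a 1.2-fold higher number from compound 2 to compound 3 (0.08 log units; within the scatter) and so does not separate the two groups. The same exchange in the opposite direction on the other substituted ring gives an at least 3.2-fold lower number from compound 1 to compound 3 (0.50 log units; beyond the scatter), so the tolerated concentration responds to this change there but not here. Compound 1 gives a limit and not a number: the limit of > 100000 nM in this assay, at which 1 of the 3 values shown sits.

From the compounds shown here alone, whether an amine, a carboxylic acid or a methoxy group at either place would move the number stays open. So does how far the step on the other ring truly reaches.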